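Replacing the Long Chain on the Aromatic Oxygen

The source may hold more compounds than are shown below. What is called first, only, known or untested is meant among the compounds shown, and "the series" means these compounds.

Among the three measured compounds, compound 2 `CC(C)=CCC/C(C)=C/COc1cc(=O)n(CCCO)c2c1CC(CC=C(C)C)C(C)(C)C2` stands lowest, giving 10.6% in a functional assay on PANC-1 cells (Homo sapiens) for inhibition, read by MTT assay, with a stated time of 24 h, tested at 10 uM; a higher number here means more inhibition at the concentration tested (going by the name of the read-out), a lower number less inhibition. Compound 1 `CCOc1cc(=O)n(CCCO)c2c1CC(CC=C(C)C)C(C)(C)C2` gives 66.5% and compound 3 `CC(C)=CCC1Cc2c(OCCCOc3ccc([N+](=O)[O-])cc3)cc(=O)n(CCCO)c2CC1(C)C` gives 47.5%. Compound 4 `COc1cccc(NC(=O)Oc2cc(=O)n(CCCO)c3c2CC(CC=C(C)C)C(C)(C)C3)c1` differs from compound 2 by (3-methoxyphenyl)carbamoyl in place of 3,7-dimethylocta-2,6-dien-1-yl on an oxygen on an aromatic ring. Going by the values given here, two measured steps bear on this change: a number 55.9 percentage points lower from compound 1 to compound 2 (beyond the scatter) and a number 36.9 percentage points higher from compound 2 to compound 3 (beyond the scatter). Both show that the 3,7-dimethylocta-2,6-dien-1-yl chain on the aromatic oxygen goes with the lowest number, and that another group in its place gives a much higher one. Among the compounds with values here, a large rise is therefore expected in this assay when that chain leaves and (3-methoxyphenyl)carbamoyl enters, although no measured compound carries a carbamoyl group on that oxygen. Compound 4 is estimated at 50%, within 25% to 75%, an expected step of a number 39.4 percentage points higher from compound 2 to compound 4 (beyond the scatter).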

Compound 4, a percentage reported as inhibition, at one concentration (the size of the read-out at that concentration, not a potency): 16.2%
Compound 4: the middle estimate sits 33.8 percentage points above what was measured; measured number outside the range, below it.
By their numbers in this assay, from the lowest: compounds 2 and 4 (each within the scatter of the next); then compound 3; then compound 1.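

In this assay the step is a number 5.6 percentage points higher from compound 2 to compound 4 (within the scatter), so removing the 3,7-dimethylocta-2,6-dien-1-yl chain from this oxygen does not by itself bring a high number. The ethyl group of compound 1 also holds well clear of the carbamoyl, with a number 50.3 percentage points lower from compound 1 to compound 4 (beyond the scatter), so a low number at this position is not tied to that chain alone. Nothing available explains this result. Going by these compounds, whether a propyl group on this oxygen would hold the number of compound 1 stays open. So does what a short chain ending in an amine would give there.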